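The source may hold more compounds than are shown below. What is called first, only, known or untested is meant among the compounds shown, and "the series" means these compounds.

Measured in an ADME assay on S9 fraction from liver (Homo sapiens) for metabolic stability, with a stated time of 1 h; on this read-out higher numbers stand for a more stable compound and lower numbers for a less stable compound:
- compound 1 `CC(C)(F)c1ncncc1CNc1cc(N[C@H]2CC[C@@H](O)CC2)c(C#N)cn1`: 89%
- compound 2 `COc1ncncc1CNc1cc(N[C@H]2CC[C@@H](O)CC2)c(C#N)cn1`: 88%

Within the data shown here, compound 2, at 88%, cannot be separated from the only other measured compound. Among the measured compounds shown here, the single measured step is a number 1 percentage points lower from compound 1 to compound 2 (within the scatter).

Compound 3 `CC(C)(C)Oc1ncncc1CNc1cc(N[C@H]2CC[C@@H](O)CC2)c(C#N)cn1` is the next structure to read out. The change is tert-butyl in place of methyl on an oxygen on an aromatic ring, that is, methoxy to tert-butoxy. For the measured compounds named here, no measured compound carries tert-butoxy, so the data hold no direct measure of this change. The nearest evidence is a number 1 percentage points lower from compound 1 to compound 2 (within the scatter), where a different group on the same aromatic carbon made no difference beyond the scatter. That is one step only, so it is weak support. The expected result in this assay is a number 3 percentage points lower from compound 2 to compound 3 (within the scatter), which would be no shift beyond the scatter. For compound 3 the estimated value is 85%, with an expected range of 70% to 94%.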

Compound 3, percent of the compound remaining: 54%
Estimate against measurement, compound 3: 31 percentage points above; the whole stated range lies above it.
By their numbers in this assay, from the lowest: compound 3; then compounds 2 and 1 (each within the scatter of the next).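

In this assay the group on this aromatic carbon can matter: going from methoxy to tert-butoxy, from 1 heavy atom to 4 in the part that changes, gives a number 34 percentage points lower from compound 2 to compound 3 (beyond the scatter) and so is a large step, which the earlier pair within the scatter did not reveal. The comparison with the carbon-linked group gives a number 35 percentage points lower from compound 1 to compound 3 (beyond the scatter) and so shows that 1-fluoro-1-methylethyl and tert-butoxy do not read alike at this position. Nothing measured here gives a reason for the loss.

The compounds shown leave open whether the loss grows gradually with the group on the oxygen or appears only with tert-butyl; ethoxy or isopropoxy would lie between the two ends. They also leave open how an amine on the same aromatic carbon would read.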